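Piperidine amide in place of primary amide on compound 3

A few compounds are considered here, and "the series" means these few. Any claim that something is new, unique, unknown or untested is made for them only; others in the source may bear on it.

Measured in an assay on AV12 cells for binding affinity to Neuropeptide Y receptor type 1 (Homo sapiens); a higher number here means a weaker inhibitor, a lower number a stronger inhibitor:
compound 1, `Cc1cccc2c1nc(COc1ccc(Cl)cc1)n2CCCC1CCNCC1`, 335 nM
compound 2, `Cc1cccc2c1nc(COc1ccc(Cl)cc1)n2CCCC1CCN(CCC(C)C)CC1`, 11 nM
compound 3, `Cc1cccc2c1nc(COc1ccc(Cl)cc1)n2CCCC1CCN(CCCC(N)=O)CC1`, 88 nM

Compound 3 holds the second highest of the three numbers: it lies nearer to compound 1, a 3.8-fold lower number from compound 1 to compound 3 (0.58 log units; beyond the scatter), than to compound 2, an 8.0-fold higher number from compound 2 to compound 3 (0.90 log units; beyond the scatter). Compound 4, `Cc1cccc2c1nc(COc1ccc(Cl)cc1)n2CCCC1CCN(CCCC(=O)N2CCCCC2)CC1`, has not yet been measured in this assay. It differs from compound 3 in one place: piperidin-1-yl in place of amino on a carbonyl carbon.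

Going by the values given here, two measured steps bear on this change. Adding isopentyl at the ring amine gave a 30-fold lower number from compound 1 to compound 2 (1.48 log units; beyond the scatter), while adding 3-carbamoylpropyl gave only a 3.8-fold lower number from compound 1 to compound 3 (0.58 log units; beyond the scatter), and the pair of the two substituents reads an 8.0-fold higher number from compound 2 to compound 3 (0.90 log units; beyond the scatter). Both steps leaving compound 1 went down, and the larger one came with the substituent that carries no carbamoyl group. Compound 4 keeps the carbonyl but trades the amino for piperidin-1-yl, with a six-membered ring of five carbons and one nitrogen. On this basis compound 4 is expected to sit between compound 3 and compound 2, with an estimated step of a 2.9-fold lower number from compound 3 to compound 4 (0.47 log units; beyond the scatter), downward and beyond the scatter. The estimate for compound 4 in this assay is 30 nM, within a range from 8 nM to 120 nM.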

Compound 4, inhibition constant: 21 nM
Estimate against measurement, compound 4: 1.4-fold (0.15 log units) above; measured number inside the range.
By their numbers in this assay, from the lowest: compounds 2 and 4 (each within the scatter of the next); then compound 3; then compound 1.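

In this assay, piperidin-1-yl in place of amino on the carbonyl carbon gives a 4.2-fold lower number from compound 3 to compound 4 (0.62 log units; beyond the scatter), so the group on this carbonyl carbon clearly affects the result, and the modest result for compound 3 does not apply to every substituent carrying this carbonyl. The carbonyl itself is no bar to a low number: the comparison with the isopentyl compound reads a 1.9-fold higher number from compound 2 to compound 4 (0.28 log units; within the scatter), which lies within the scatter, so the two cannot be told apart here although only one of them carries a carbonyl. Set against hydrogen on the amine nitrogen in the ring, the whole 3-((piperidin-1-yl)carbonyl)propyl substituent gives a 16-fold lower number from compound 1 to compound 4 (1.20 log units; beyond the scatter), a large step that the earlier compounds had shown only with isopentyl.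

Nothing in the material gives a measured reason for the change on the carbonyl carbon. As far as these compounds go, it remains open whether the step depends on the six-membered ring or only on replacing the amide hydrogens, a question that dimethylamino or morpholin-4-yl on the same carbonyl carbon could address, and the effect of a longer chain carrying this carbonyl is also unknown.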